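Second trifluoromethyl on the terminal urea aryl ring

The source may report more compounds than this note shows. Statements on the series, on what has been measured and on what is new or still open speak of the compounds shown alone.

For the measured compounds named here, compound 1 `O=C(Nc1cccc(-n2cc(-c3ccncc3)c(-c3ccc(Cl)c(O)c3)n2)c1)Nc1cccc(C(F)(F)F)c1` gives 12600 nM in a functional assay on MDA-MB-435 cells (Homo sapiens) for inhibition, read by sulforhodamine B assay, with a stated time of 48 h (on this read-out lower numbers stand for stronger inhibition of growth and higher numbers for weaker inhibition of growth), the highest of the three numbers measured so far. Compound 2 `O=C(Nc1cccc(-n2cc(-c3ccncc3)c(-c3ccc(Cl)c(O)c3)n2)c1)Nc1ccc(Cl)c(Cl)c1` stands nearest, with 6050 nM in this assay, and compound 3 `COc1cc(-c2nn(-c3cccc(NC(=O)Nc4cccc(C(F)(F)F)c4)c3)cc2-c2ccncc2)ccc1Cl` furthest, with 2140 nM in this assay. The step from compound 1 to compound 2 (a 2.1-fold lower number from compound 1 to compound 2 (0.32 log units; beyond the scatter)) moved the number modestly; the step from compound 1 to compound 3 (a 5.9-fold lower number from compound 1 to compound 3 (0.77 log units; beyond the scatter)) moved it further, but that change sits on the phenol oxygen, not on the urea aryl ring.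

Compound 4 `O=C(Nc1cccc(-n2cc(-c3ccncc3)c(-c3ccc(Cl)c(O)c3)n2)c1)Nc1cc(C(F)(F)F)cc(C(F)(F)F)c1` differs from compound 1 by trifluoromethyl in place of hydrogen on an aromatic carbon, on the same terminal aryl ring that was altered in the step from compound 1 to compound 2. Going by the values given here, only that step bears directly on the present change, and it was modest. Among the compounds with values here, no measured step shows what a second trifluoromethyl on this ring does, so the expectation rests on the direction of the step from compound 1 to compound 2 alone, and a modest lowering of the number in this assay is expected for compound 4, with a wide range around it.

For compound 4 the expected value in this assay is 6500 nM, between 2500 nM and 16000 nM, corresponding to an expected step of a 1.9-fold lower number from compound 1 to compound 4 (0.29 log units; within the scatter).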

Compound 4, concentration for total growth inhibition: 2590 nM
For compound 4 the middle estimate is 2.5-fold (0.40 log units) above the measured one, within the range that was stated.
By their numbers in this assay, from the lowest: compounds 3 and 4 (each within the scatter of the next); then compound 2; then compound 1.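

The terminal urea aryl ring takes a second trifluoromethyl, on an aromatic carbon meta to a trifluoromethyl group, and in this assay this gives stronger growth inhibition, with a 4.9-fold lower number from compound 1 to compound 4 (0.69 log units; beyond the scatter). Until now the only change shown on this ring was the swap to 3,4-dichlorophenyl, with a 2.1-fold lower number from compound 1 to compound 2 (0.32 log units; beyond the scatter); the new step shows that adding a group to compound 1 at this ring, with the first trifluoromethyl kept in place, also lowers the number, so both changes on this ring point the same way. No measured property of these compounds bears on this result, so the step stands as an observation without an explanation.

Whether the lowering is specific to trifluoromethyl at this carbon remains open, since the compounds shown include no nitrile, carboxylic acid, amine or single fluorine there. Also open is whether the step on this ring would add to the methyl on the phenol oxygen, which gave a 5.9-fold lower number from compound 1 to compound 3 (0.77 log units; beyond the scatter), as the compounds shown do not carry both changes together.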